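This account rests on a few compounds, and the source may have more. Where it says the series, first, only, none or still open, it means among the compounds named here.

Compound 1 `COc1ccc(/C=C/C(=O)Nc2cc(-c3ccc(Br)cc3)[nH]n2)cc1` gives 770 nM
Compound 2 `Cc1ccc(-c2cc(NC(=O)/C=C/c3ccc(C(F)(F)F)cc3)n[nH]2)cc1` gives 1210 nM
Compound 3 `O=C(/C=C/c1ccc([N+](=O)[O-])cc1)Nc1cc(-c2ccccc2)[nH]n1` gives 720 nM

All three values come from a functional assay on B16-F10 cells (Mus musculus) for antiproliferative activity, read by MTT assay, with a stated time of 48 h (on this read-out higher numbers stand for weaker inhibition and lower numbers for stronger inhibition), and no two of these compounds differ in one place only. Compound 2 at 1210 nM lies within the scatter of both compound 1 and compound 3, so the numbers give no order among them.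

The change from compound 2 to compound 4 `Cc1ccc(-c2cc(NC(=O)/C=C/c3ccc(Br)cc3)n[nH]2)cc1` is bromo in place of trifluoromethyl on an aromatic carbon, para to a large group bromo in place of trifluoromethyl on an aromatic carbon and nothing else differs. Within the data shown here, no measured pair shows this exchange, so in this assay no step beyond the scatter is expected in either direction. Bromo also occurs in compound 1 at 770 nM but in another place, which makes that value only a loose guide. The estimate amounts to a 1.3-fold lower number from compound 2 to compound 4 (0.13 log units; within the scatter) and stays within the scatter. For compound 4 the expected value is 900 nM with an estimated range from 400 nM to 2000 nM as the likely span.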

Compound 4, half-maximal inhibitory concentration: 1570 nM
Compound 4: the middle estimate sits 1.7-fold (0.24 log units) below what was measured; measured number inside the range.
By their numbers in this assay, from the lowest: compounds 3, 1, 2 and 4 (each within the scatter of the next, the first and the last beyond it).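

In this assay, the exchange of trifluoromethyl for bromo at this place reads as a 1.3-fold higher number from compound 2 to compound 4 (0.11 log units; within the scatter), the first direct view of this change in the series. On an aromatic carbon, para to a large group, four heavy atoms leave and one enters, with no hydrogen-bond donor or acceptor on either side, and in this one pair the number does not move beyond the scatter.

Going by these compounds, whether an amine or a carboxylic acid at this place would stay as close to these two groups remains open, as does whether the same exchange reads alike with other groups elsewhere on the shared core. No measurement at hand speaks to why bromo and trifluoromethyl read alike here.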